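Amide nitrogen substituent change in a chemokine receptor antagonist series

The source may report more compounds than this note shows. Statements on the series, on what has been measured and on what is new or still open speak of the compounds shown alone.

Measured so far in a functional assay for antagonist activity at C-X-C chemokine receptor type 3 (Homo sapiens); on this read-out higher numbers stand for weaker inhibition and lower numbers for stronger inhibition:
compound 1 `CC(C)NC(=O)c1cnc(N2CCN(C3CCN(Cc4ccc(Cl)cc4)CC3)[C@@H](C)C2)c(Cl)c1` gives 5 nM
compound 2 `C[C@H]1CN(c2ncc(C(=O)NCC3CCCCC3)cc2Cl)CCN1C1CCN(Cc2ccc(Cl)cc2)CC1` gives 2.4 nM

Compound 2 holds the lowest of the two numbers; its nearest neighbour is compound 1, with a 2.1-fold lower number from compound 1 to compound 2 (0.32 log units; beyond the scatter).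

Compound 3 `C[C@H]1CN(c2ncc(C(=O)Nc3ccc(F)c(F)c3)cc2Cl)CCN1C1CCN(Cc2ccc(Cl)cc2)CC1` differs from compound 2 in one place: 3,4-difluorophenyl in place of cyclohexylmethyl on an amide-type nitrogen. For the measured compounds named here, the single measured step, a 2.1-fold lower number from compound 1 to compound 2 (0.32 log units; beyond the scatter), concerns two non-aromatic groups on the same nitrogen and gives no direct guidance on an aromatic replacement; no measured step bears on this change. The expectation for compound 3 is therefore a step near the scatter, a 1.7-fold higher number from compound 2 to compound 3 (0.22 log units; within the scatter), with no firm direction. Compound 3 is estimated at 4 nM, within 1 nM to 20 nM.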

Compound 3, half-maximal inhibitory concentration: 22 nM
The estimate for compound 3 lay 5.5-fold (0.74 log units) below the measured number, and the stated range ends below it.
By their numbers in this assay, from the lowest: compound 2; then compound 1; then compound 3.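

In this assay the 3,4-difluorophenyl group on the amide-type nitrogen gives a 9.2-fold higher number from compound 2 to compound 3 (0.96 log units; beyond the scatter) and a 4.4-fold higher number from compound 1 to compound 3 (0.64 log units; beyond the scatter) as the comparison with the smaller isopropyl group. This position therefore tolerates isopropyl and cyclohexylmethyl better than this aromatic ring, and compound 3 is the weakest of the three. Nothing available explains this loss of inhibition.

Still open, from the compounds shown here alone, is whether the loss follows from the aromatic ring itself or from its two fluorines. Unsubstituted phenyl and benzyl on this nitrogen would separate those readings.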